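Dithiocarbamate amine swap on a benzamide scaffold

The compounds below may be only part of what the source reports. "The series", "measured", "known", "first", "only" and "open" are said of these compounds alone.

Measured compounds:
compound 1, `CC1CCN(C(=S)SCc2ccc(C(=O)Nc3ccccc3N)cc2)CC1`, 46.8%
compound 2, `Nc1ccccc1NC(=O)c1ccc(CSC(=S)N2CCN(c3cnccn3)CC2)cc1`, 70.4%

Going by the values given here, in a functional assay on HeLa cells (Homo sapiens) for antiproliferative activity, read by CCK-8 assay, with a stated time of 72 h, tested at 2 uM (a lower number here means a weaker effect, a higher number a stronger effect of the compound at the concentration tested), compound 1 gives 46.8%, the lower of the two numbers known so far. Compound 2 in this assay gives 70.4%, a result that lies beyond the scatter above compound 1. Among the compounds with values here, no pair of compounds here differs in only one place, so no single step can be traced between them.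

Compound 3, `Nc1ccccc1NC(=O)c1ccc(CSC(=S)N2CCc3ccccc32)cc1`, has not yet been tested. It differs from compound 1 by 2,3-dihydro-1H-indol-1-yl in place of 4-methylpiperidin-1-yl on a thiocarbonyl carbon. Without a measured step of this kind, only an expectation is possible. The step from compound 1 to compound 3 in this assay is expected to be a modest rise, a number 8.2 percentage points higher from compound 1 to compound 3 (within the scatter), one that might not clearly exceed the scatter. Compound 3 is thus estimated to give 55%, with a range from 35% to 75%.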

Compound 3, a percentage reported as inhibition, at one concentration (the size of the read-out at that concentration, not a potency): 38%
Estimate against measurement, compound 3: 17 percentage points above; the range from low to high includes it.
By their numbers in this assay, from the lowest: compounds 3 and 1 (each within the scatter of the next); then compound 2.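

In this assay, going by these compounds alone, the exchange of 4-methylpiperidin-1-yl for 2,3-dihydro-1H-indol-1-yl on a thiocarbonyl carbon gives the first step that can be traced at this position, a number 8.8 percentage points lower from compound 1 to compound 3 (within the scatter), so this step does not separate the two compounds. The position thus accepts a group with one five-membered non-aromatic ring and one six-membered aromatic ring of carbon only in place of a single six-membered non-aromatic ring, with no difference beyond the usual spread of repeats. Nothing available accounts for this outcome.

One step at one position gives no trend, and it cannot show whether the aromatic ring or the smaller non-aromatic ring matters more. On these data alone, how an open-chain diethylamino group or a morpholin-4-yl group would fare on the same thiocarbonyl carbon remains open.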